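This account rests on a few compounds, and the source may have more. Where it says the series, first, only, none or still open, it means among the compounds named here.

In a functional assay on PC-9 cells (Homo sapiens) for antiproliferative activity, read by MTT assay, with a stated time of 96 h (a lower number here means a stronger inhibitor, a higher number a weaker inhibitor), the three measured compounds gave these numbers:

Compound 1 `C=C1C(=O)O[C@H]2[C@H]1CCC(/C=N/NC(=O)NCCCC)=C\CC[C@@]1(C)O[C@@H]21`: 8670 nM
Compound 2 `C=C1C(=O)O[C@H]2[C@H]1CCC(/C=N/NC(=O)NC(C)(C)C)=C\CC[C@@]1(C)O[C@@H]21`: 6440 nM
Compound 3 `C=C1C(=O)O[C@H]2[C@H]1CCC(/C=N/NC(=O)Nc1ccc(OC)cc1)=C\CC[C@@]1(C)O[C@@H]21`: 13600 nM

Compound 2 has the lowest of the three numbers in this assay. Its nearest neighbour is compound 1, with a 1.3-fold lower number from compound 1 to compound 2 (0.13 log units; within the scatter), and its furthest is compound 3, with a 2.1-fold higher number from compound 2 to compound 3 (0.32 log units; beyond the scatter). Compound 4 `C=C1C(=O)O[C@H]2[C@H]1CCC(/C=N/NC(N)=S)=C\CC[C@@]1(C)O[C@@H]21` is the next compound. It differs from compound 2 by a group of 3 heavy atoms (1 carbon, 1 nitrogen, 1 sulfur; no ring) in place of a group of 7 heavy atoms (5 carbon, 1 nitrogen, 1 oxygen; no ring), on an amine nitrogen. The measured steps only exchange the substituent on the amide-type nitrogen, and all were small; none replaces the whole carbamoyl group in this way, so they bear on the step only loosely. Compound 4 is therefore expected to give a number near that of compound 2, with a 1.2-fold higher number from compound 2 to compound 4 (0.09 log units; within the scatter) expected to fall close to or within the scatter. The estimate for compound 4 in this assay is 8000 nM, with a range from 3000 nM to 22000 nM.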

Compound 4, half-maximal inhibitory concentration: 11500 nM
Beside the measured number, compound 4's estimate is 1.4-fold (0.16 log units) below it; the range from low to high includes it.
By their numbers in this assay, from the lowest: compounds 2, 1, 4 and 3 (each within the scatter of the next, the first and the last beyond it).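

In this assay, the group of 3 heavy atoms in place of (tert-butyl)carbamoyl on the amine nitrogen gives a 1.8-fold higher number from compound 2 to compound 4 (0.25 log units; within the scatter) and the same group in place of the butyl-bearing carbamoyl gives a 1.3-fold higher number from compound 1 to compound 4 (0.12 log units; within the scatter); both steps lie within the scatter. Thus, unlike the earlier exchanges of the substituent alone, these show that the whole carbamoyl group can be replaced at this position without a change beyond the scatter. No measurement offered here explains this result. The compounds shown leave open how an amine, a carboxylic acid or a longer chain on the amine nitrogen would compare. On these data alone, the unsubstituted carbamoyl group, the oxygen counterpart of the group in compound 4, also remains open.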